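Swapping a Nitro Aryl for a Methoxy Aryl

The source may report more compounds than this note shows. Statements on the series, on what has been measured and on what is new or still open speak of the compounds shown alone.

In a toxicity assay (Homo sapiens) for cytotoxicity, read by MTT assay, with a stated time of 48 h (on this read-out lower numbers stand for stronger inhibition and higher numbers for weaker inhibition), compound 1 `O=C1C(O)=C(C(c2cccc([N+](=O)[O-])c2)c2c[nH]c3ccccc23)C(=O)c2ccccc21` gives 91200 nM, the higher of the two numbers at hand. Compound 2 `O=C1C(O)=C(C(c2ccc([N+](=O)[O-])cc2)c2c(-c3ccccc3)[nH]c3ccccc23)C(=O)c2ccccc21`, which carries further changes elsewhere, gives 14200 nM, a gap beyond the usual scatter. Compound 3 `COc1ccccc1C(C1=C(O)C(=O)c2ccccc2C1=O)c1c[nH]c2ccccc12` has not been measured. It differs from compound 1 in a single place: 2-methoxyphenyl in place of 3-nitrophenyl on a saturated chain carbon bound to an aromatic carbon and a double-bonded ring carbon. For the measured compounds named here, no measured pair shows this exact change, so its effect is uncertain; a modest step is expected, with a lower number somewhat more likely than a higher one, and the expected step of a 1.4-fold lower number from compound 1 to compound 3 (0.15 log units; within the scatter) may well stay within the scatter. For compound 3 the estimate is 65000 nM, ranging from 20000 nM to 200000 nM.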

Compound 3, half-maximal inhibitory concentration: > 200000 nM
Compound 3 was reported as a limit; the forecaster's own chance of this, stated with the estimate: 10%; at least 3.0-fold (0.48 log units) between middle value and limit.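

At the saturated chain carbon bound to an aromatic carbon and a double-bonded ring carbon, the aryl group matters: in this assay, 2-methoxyphenyl in place of 3-nitrophenyl gives an at least 2.1-fold higher number from compound 1 to compound 3 (0.34 log units; beyond the scatter). A higher number means weaker inhibition, so this single-place change weakens the effect, whereas the earlier pair differed in more than one place. The result for compound 3 is a limit of the assay, not a number: the limit of > 200000 nM in this assay, at which 1 of the 3 values shown sits.

As far as these compounds go, how far compound 3 lies past that limit stays open. So does whether the methoxy group itself or its place on the ring drives the step, which a plain phenyl or a 3-methoxyphenyl group at this carbon would help separate.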